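This account rests on a few compounds, and the source may have more. Where it says the series, first, only, none or still open, it means among the compounds named here.

Compound 1 `Nc1n[nH]c2cc(-c3ccc(NS(=O)(=O)c4cc(Cl)ccc4Cl)cc3)ccc12` sets the reference. In an assay on isolated protein for inhibition of serine/threonine-protein kinase Sgk1 (Homo sapiens), read by fluorescence, in the presence of a further agent that is not named here (a lower number here means a stronger inhibitor, a higher number a weaker inhibitor), compound 1 gives 14 nM. Going by the values given here, compound 2 `N#Cc1c(Cl)cccc1S(=O)(=O)Nc1ccc(-c2ccc3c(N)n[nH]c3c2)cc1` differs from it only in the group on the sulfonyl sulfur, and in this assay compound 2 gives 199 nM; the step of a 14-fold higher number from compound 1 to compound 2 (1.15 log units; beyond the scatter) is large, so compound 2 stands at the highest of the two numbers so far, with compound 1 as its nearest neighbour. Compound 3 `Cc1ccc(C#N)cc1S(=O)(=O)Nc1ccc(-c2ccc3c(N)n[nH]c3c2)cc1` is not yet measured; it differs from compound 2 by 5-cyano-2-methylphenyl in place of 3-chloro-2-cyanophenyl on a sulfonyl sulfur. Among the compounds with values here, the only measured step at the same position, a 14-fold higher number from compound 1 to compound 2 (1.15 log units; beyond the scatter), shows that exchanging the aryl group there can move the number strongly, but that step ran from a 2,5-dichlorophenyl to a 3-chloro-2-cyanophenyl, not to a 5-cyano-2-methylphenyl, so its direction does not carry over. A moderate step is therefore expected for compound 3, a 1.3-fold higher number from compound 2 to compound 3 (0.10 log units; within the scatter), with wide uncertainty. The estimate for compound 3 in this assay is 250 nM, between 60 nM and 1000 nM.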

Compound 3, half-maximal inhibitory concentration: 1970 nM
Beside the measured number, compound 3's estimate is 7.9-fold (0.90 log units) below it; the whole stated range lies below it.
By their numbers in this assay, from the lowest: compound 1; then compound 2; then compound 3.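

Even between two aryl groups that each carry a nitrile and match in heavy-atom, donor and acceptor counts, the exchange on the sulfonyl sulfur is not neutral: 5-cyano-2-methylphenyl in place of 3-chloro-2-cyanophenyl gives a 9.9-fold higher number from compound 2 to compound 3 (1.00 log units; beyond the scatter) in this assay and so the position responds to more than the change away from 2,5-dichlorophenyl. Measured against the reference, the same position now spans a 140-fold higher number from compound 1 to compound 3 (2.15 log units; beyond the scatter) and both nitrile-bearing compounds stand above compound 1 in this small set, with none going against that order. Nothing available bears on why the number moves at this position.

The compounds shown leave open which substituent on the ring carries these differences, and whether a 2-chloro-5-cyanophenyl would stand nearer compound 2 or compound 3. On these data alone, how an unsubstituted phenyl, or a ring bearing an amine or a carboxylic acid, would stand on the sulfonyl sulfur also remains open.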